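Opening the Ether Ring: From Compound 2 to Compound 4

This account rests on a few compounds, and the source may have more. Where it says the series, first, only, none or still open, it means among the compounds named here.

Measured so far in an assay on cells with melanin-concentrating hormone receptor 1 (Homo sapiens) as the target, read by radioligand binding; a higher number here means a weaker inhibitor, a lower number a stronger inhibitor:
compound 1 `CC1CCCCC1Oc1cccc2ccc(N)nc12`: 32 nM
compound 2 `Nc1ccc2cccc(OCC3CCCO3)c2n1`: > 2000 nM
compound 3 `CC(CC(C)(C)C)Oc1cccc2ccc(N(C)C)nc12`: > 2000 nM

Of the three, only compound 1 has a number; in this assay compound 1 gives 32 nM. For compound 2 the result in this assay is only a limit, > 2000 nM. For compound 3 the result is likewise a limit, > 2000 nM. Compound 2 therefore sits at the limit of > 2000 nM in this assay, at which 2 of the 3 values shown sit, and no true value for it is known, only that it is weaker than that limit allows to show.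

Compound 4 `CC(C)OCCOc1cccc2ccc(N)nc12` differs from compound 2 in one place: isopropoxymethyl in place of oxolan-2-yl on a saturated chain carbon bound to an oxygen on an aromatic ring. The ring of the side chain is opened, and a flexible ether chain of the same kind of atoms takes its place; the shared core of compound 2 is untouched.

Among the compounds with values here, no step between measured compounds is available to guide the size of this change. Because compound 2 gives only the limit > 2000 nM, the change from compound 2 to compound 4 cannot be measured against anything, and it is expected to be about none beyond the scatter, a step that the limit leaves unreadable from compound 2 to compound 4. Compound 4 is expected to give roughly 3000 nM, somewhere between 800 nM and 12000 nM, most likely again reported only as a limit.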

Compound 4, half-maximal inhibitory concentration: > 2000 nM
Compound 4: only a limit was reported; the forecaster's own chance of this, stated with the estimate: 60%; the middle value does not contradict the limit.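

In this assay compound 4 gives > 2000 nM, which is only a limit. Within the data shown here, compound 2 also stands at a limit, so no step from compound 2 to compound 4 can be read. The compounds shown leave open whether isopropoxymethyl in place of oxolan-2-yl changes the true strength at all.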